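The source may hold more compounds than are shown below. What is called first, only, known or untested is meant among the compounds shown, and "the series" means these compounds.

Measured compounds in an ADME assay on MDCK-MDR1 cells (Canis lupus familiaris) for permeability, in the apical to basolateral direction, with a stated time of 180 min; a higher number here means that the compound crosses the layer faster, a lower number that the compound crosses the layer more slowly:
- compound 1, `COCCC(=O)Nc1ccc(C2CCCCC2)cc1`, gives 22.2 10^-6 cm/s
- compound 2, `COCCC(=O)Nc1ccc([C@H]2[C@@H](F)[C@@H](F)C[C@@H](F)[C@H]2F)cc1`, gives 18.1 10^-6 cm/s
- compound 3, `O=C(Cn1ccnc1)Nc1ccc([C@H]2[C@@H](F)[C@@H](F)C[C@@H](F)[C@H]2F)cc1`, gives 0.9 10^-6 cm/s

Compound 1 and compound 2 lie within the scatter of each other in this assay; the difference between their two cores is not broken down here. Within the data shown here, the one measured step within the set is the change from compound 2 to compound 3, (1H-imidazol-1-yl in place of methoxymethyl on a saturated chain carbon bound to a carbonyl carbon), which gives a 20-fold lower number from compound 2 to compound 3 (1.30 log units; beyond the scatter).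

Compound 4, `O=C(Cn1ccnc1)Nc1ccc(C2CCCCC2)cc1`, has not yet been measured in this assay. It stands to compound 1 as compound 3 stands to compound 2: the change is 1H-imidazol-1-yl in place of methoxymethyl on a saturated chain carbon bound to a carbonyl carbon, and the place is the same for both pairs, so this is the same change made on the core of compound 1 rather than on the core of compound 2. This change occurs twice among the compounds shown, once measured and once not.

Among the measured compounds shown here, the expectation for compound 4 in this assay rests on the one measured instance: the step from compound 1 to compound 4 is expected to be of about the size seen from compound 2 to compound 3, that is a 17-fold lower number from compound 1 to compound 4 (1.23 log units; beyond the scatter). This rests on compound 2 giving 18.1 10^-6 cm/s and compound 1 giving 22.2 10^-6 cm/s, two starting values within the scatter of each other, and on the drop a 20-fold lower number from compound 2 to compound 3 (1.30 log units; beyond the scatter) being large and beyond the scatter. For the measured compounds named here, with only one measured example of the change, the width of the range is set generously. Compound 4 is therefore estimated at 1.3 10^-6 cm/s in this assay, with a range from 0.5 10^-6 cm/s to 4 10^-6 cm/s.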

Compound 4, apparent permeability: 11.1 10^-6 cm/s
Compound 4: the middle estimate sits 8.5-fold (0.93 log units) below what was measured, and the stated range ends below it.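

In this assay, the change from methoxymethyl to 1H-imidazol-1-yl on a saturated chain carbon bound to a carbonyl carbon gives a 2.0-fold lower number from compound 1 to compound 4 (0.30 log units; within the scatter), so on this core the step stays within the scatter. Among these compounds, the size of the step therefore does not carry over between the two cores, and a single measured instance on one core is a poor guide to the other: the same change on two cores in this assay, a 20-fold lower number (1.30 log units; beyond the scatter) from compound 2 to compound 3 and a 2.0-fold lower number (0.30 log units; within the scatter) from compound 1 to compound 4, 10-fold (1.00 log units) apart, beyond the scatter of two such steps This shows that the result of the change depends on the core, but it rests on only two pairs, and it does not show which part of the difference between the two cores is responsible, nor why the steps diverge.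

The compounds shown leave open whether this dependence on the core is specific to 1H-imidazol-1-yl or also holds for other groups in the same place, such as a tertiary amine, a carboxylic acid or a longer chain ending in 1H-imidazol-1-yl. They also leave open how the step behaves on a core with only some of the fluorine atoms of compound 2, which would help locate where the divergence between the two cores arises.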